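A Second Propylamino Group on a Pyrazolopyrimidine-Type Core

The source may report more compounds than this note shows. Statements on the series, on what has been measured and on what is new or still open speak of the compounds shown alone.

Compound 1 `CCCNc1nc(C)nc2c1cnn2-c1ccccc1` carries a propylamino group and a methyl group on its shared core. In a functional assay on G-361 cells (Homo sapiens) for cytotoxicity, read by sulforhodamine B assay (on this read-out higher numbers stand for weaker inhibition of growth and lower numbers for stronger inhibition of growth), compound 1 gives > 100000 nM, which is a limit of the assay and not a number. Compound 2 `Cc1nc(NC(C)C)c2cnn(-c3ccccc3)c2n1` gives > 100000 nM in this assay, again a limit rather than a number. Compound 3 `Cc1nc(NCc2ccco2)c2cnn(-c3ccccc3)c2n1` gives > 100000 nM in this assay, also a limit. The steps between these three therefore cannot be sized: a step that the two limits leave unreadable from compound 1 to compound 2, a step that the two limits leave unreadable from compound 1 to compound 3 and a step that the two limits leave unreadable from compound 2 to compound 3 all stay unreadable, and the only firm point is the limit of > 100000 nM in this assay, at which 3 of the 3 values shown sit.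

Compound 4 `CCCNc1nc(NCCC)c2cnn(-c3ccccc3)c2n1` differs from compound 1 in one place: propylamino in place of methyl on an aromatic carbon. Among the measured compounds shown here, none of the measured steps touches this position, and none of them yields a readable size, so there is no measured guide to the direction of this change. The closest evidence is that compound 1 itself sits at a limit, > 100000 nM. The step from compound 1 to compound 4 is expected to be a number no higher from compound 1 to compound 4 (the limit leaves the size open), that is, no readable change. Compound 4 is therefore expected to give about 100000 nM, with a range from 30000 nM to 300000 nM, most likely reported again as a limit.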

Compound 4, concentration for total growth inhibition: > 100000 nM
Compound 4: no number, only a limit; the forecaster's own chance of this, stated with the estimate: 85%; the middle value lies on the limit itself.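

In this assay compound 4 gives > 100000 nM, which is a limit and not a number. The step between compound 1 and compound 4 therefore cannot be read, and the only firm point stays the same: the limit of > 100000 nM in this assay, at which 4 of the 4 values shown sit.

The compounds shown leave open whether any group on the shared core gives a measurable inhibition of growth.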